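A few compounds are considered here, and "the series" means these few. Any claim that something is new, unique, unknown or untested is made for them only; others in the source may bear on it.

Compound 1 `CCCSc1nc(N/N=C/c2cccc(Cl)c2)c2nnn(Cc3ccccc3)c2n1`: > 64000 nM (a limit)
Compound 2 `CCCSc1nc(N/N=C(\C)c2ccccc2O)c2nnn(Cc3ccccc3)c2n1`: 2310 nM

In a functional assay on MGC-803 cells (Homo sapiens) for antiproliferative activity, read by MTT assay, with a stated time of 72 h (a lower number here means a stronger inhibitor, a higher number a weaker inhibitor), compound 1 reads > 64000 nM, which is a limit and not an exact number. Among the compounds with values here, that leaves compound 2 with the only exact value so far, 2310 nM.

Compound 3 `CCCSc1nc(N/N=C(\C)c2ccc(Br)cc2)c2nnn(Cc3ccccc3)c2n1` differs from compound 2 as follows: 4-bromophenyl in place of 2-hydroxyphenyl on a carbon with a double bond to nitrogen. Within the data shown here, one measured step bears on this: an at least 27-fold lower number from compound 1 to compound 2 (1.44 log units; beyond the scatter). It is large and beyond the scatter, and it brought in the 2-hydroxyphenyl that compound 3 loses. That step also changed more than the ring, so it is only a loose guide. The expected change is a 5.2-fold higher number from compound 2 to compound 3 (0.72 log units; beyond the scatter), towards a weaker inhibitor. Compound 3 is estimated at 12000 nM, with an expected range of 3000 nM to 50000 nM.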

Compound 3, half-maximal inhibitory concentration: 6020 nM
Estimate against measurement, compound 3: 2.0-fold (0.30 log units) above, within the range that was stated.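

In this assay, the step with 4-bromophenyl in place of 2-hydroxyphenyl is a 2.6-fold higher number from compound 2 to compound 3 (0.42 log units; beyond the scatter), so activity at this carbon does not depend on the 2-hydroxyphenyl, though that group gives the lower number. The other step, an at least 10-fold lower number from compound 1 to compound 3 (1.02 log units; beyond the scatter), changes more than the ring, yet it shows that a large gain over compound 1 also occurs without the 2-hydroxyphenyl. That step starts from a limit, not an exact number: the limit of > 64000 nM in this assay, at which 1 of the 3 values shown sits.

Still open, as far as these compounds go, is whether the gain over compound 1 comes from the saturated chain carbon or from the ring. From the compounds shown here alone, it is also open how an amine or a carboxylic acid in place of the bromine would read.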